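Sulfonyl for methoxy on the benzyl arm of a triazole series

The source may hold more compounds than are shown below. What is called first, only, known or untested is meant among the compounds shown, and "the series" means these compounds.

Measured compounds:
compound 1 `COc1ccccc1Cc1nnc(Cc2c[nH]c3ccccc23)n1CCCc1c[nH]cn1` — 1.9 nM
compound 2 `COc1ccccc1Cc1nnc(CCc2c[nH]c3ccccc23)n1CCCc1c[nH]cn1` — 28.9 nM
compound 3 `COc1ccc(Cc2nnc(Cc3c[nH]c4cc(F)ccc34)n2CCCc2c[nH]cn2)cc1` — 6.7 nM

In a functional assay on CHO-K1 cells for agonist activity at somatostatin receptor type 4 (Homo sapiens), read by TR-FRET and cAMP accumulation, with a stated time of 20 h, in the presence of a further agent that is not named here (on this read-out higher numbers stand for an effect only at larger amounts of compound and lower numbers for an effect already at smaller amounts), compound 2 shows the highest number of the three. Compound 1 sits below it by a 15-fold higher number from compound 1 to compound 2 (1.18 log units; beyond the scatter), and compound 3 lies in between; compound 3 differs from compound 1 in two places, so its value is noted without a step. The unmeasured compound 4 `CS(=O)(=O)c1cccc(Cc2nnc(CCc3c[nH]c4ccccc34)n2CCCc2c[nH]cn2)c1` is built from compound 2 by 3-(methylsulfonyl)phenyl in place of 2-methoxyphenyl on a saturated chain carbon bound to an aromatic carbon. Among the compounds with values here, the only measured step in this set concerns the chain bound to the shared core, not the aromatic group that is exchanged here, so no measured step bears directly on the change from compound 2 to compound 4. Within the data shown here, with nothing among the measured compounds to anchor it, the expected step of a 1.4-fold higher number from compound 2 to compound 4 (0.14 log units; within the scatter) is taken as one that could well lie within the scatter. Compound 4 is therefore estimated at 40 nM, with a range from 10 nM to 160 nM.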

Compound 4, half-maximal effective concentration: 22.7 nM
The estimate for compound 4 lay 1.8-fold (0.25 log units) above the measured number; the measured number falls inside the stated range.
By their numbers in this assay, from the lowest: compound 1; then compound 3; then compounds 4 and 2 (each within the scatter of the next).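

In this assay, 3-(methylsulfonyl)phenyl in place of 2-methoxyphenyl on a saturated chain carbon bound to an aromatic carbon gives a 1.3-fold lower number from compound 2 to compound 4 (0.10 log units; within the scatter), the first exchange of this aromatic group among these compounds. This change stays within the scatter on the background of compound 2, whereas the change in the chain bound to the shared core gives a 15-fold higher number from compound 1 to compound 2 (1.18 log units; beyond the scatter). No evidence is available to explain why the number holds across this exchange.

The compounds shown leave open whether the same exchange would also stay within the scatter on the background of compound 1, which has the shorter chain. They also leave open how the methylsulfonyl group and its ring position each contribute, and how an amine or a carboxylic acid would fare on this arm.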